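A few compounds are considered here, and "the series" means these few. Any claim that something is new, unique, unknown or untested is made for them only; others in the source may bear on it.

Among the compounds with values here, compound 3 `O=S(=O)(Nc1ccc2oc(-c3ccccc3)nc2c1)c1ccccc1O` is the one member of this small set that gives an actual number: in an assay on cells for inhibition of HSP60/HSP10 (Homo sapiens), with a stated time of 60 min (on this read-out higher numbers stand for weaker inhibition and lower numbers for stronger inhibition), compound 3 gives 85000 nM. Compound 1 `Cc1ccc(S(=O)(=O)Nc2ccc3oc(-c4ccccc4)nc3c2)cc1` reaches only a limit of this assay, > 100000 nM. Compound 2 `O=S(=O)(Nc1ccc2oc(-c3ccccc3)nc2c1)c1ccccc1Cl` likewise stops at a limit, > 100000 nM. The steps from these two to compound 3, an at least 1.1-fold lower number from compound 1 to compound 3 (0.07 log units; that floor lies within the scatter) and an at least 1.1-fold lower number from compound 2 to compound 3 (0.07 log units; that floor lies within the scatter), have floors within the scatter, and a step that the two limits leave unreadable from compound 1 to compound 2 cannot be read at all, because of the limit of > 100000 nM in this assay, at which 2 of the 3 values shown sit. Compound 4 `O=S(=O)(Nc1ccc2oc(-c3ccccc3)nc2c1)c1ccc(Cl)s1` carries 5-chlorothiophen-2-yl in place of 2-hydroxyphenyl on a sulfonyl sulfur. Within the data shown here, no measured step exchanges a benzene ring for a thiophene, so the three weak results are the only guide; the estimate for compound 4 is 100000 nM, between 40000 nM and 300000 nM, an expected step of a 1.2-fold higher number from compound 3 to compound 4 (0.07 log units; within the scatter).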

Compound 4, half-maximal inhibitory concentration: 70000 nM
Compound 4: middle estimate off by 1.4-fold (0.15 log units), on the high side; measured number inside the range.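

Replacing 2-hydroxyphenyl with 5-chlorothiophen-2-yl on the sulfonyl sulfur changes the ring and removes the hydrogen-bond donor, yet in this assay the result is only a 1.2-fold lower number from compound 3 to compound 4 (0.08 log units; within the scatter). The comparisons with the two compounds at a limit give an at least 1.4-fold lower number from compound 2 to compound 4 (0.15 log units; that floor lies within the scatter) and an at least 1.4-fold lower number from compound 1 to compound 4 (0.15 log units; that floor lies within the scatter). The full size of these two steps cannot be read, because they start from a limit: the limit of > 100000 nM in this assay, at which 2 of the 4 values shown sit.

As far as these compounds go, whether an amine or a carboxylic acid on the sulfonyl sulfur would give a clearly lower number remains open. So does the effect of any change on the shared core.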